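This account rests on a few compounds, and the source may have more. Where it says the series, first, only, none or still open, it means among the compounds named here.

Measured so far in an ADME assay on a cell-free system (plasma, Homo sapiens) for protein binding:
- compound 1 `CNc1nccc(N2CC[C@H](NC(=O)Nc3ccc(CN(C)C)c(C(F)(F)F)c3)C2)n1`: 94.3%
- compound 2 `CNc1nccc(N2CC[C@H](NC(=O)Nc3ccc(OC)cc3)C2)n1`: 80%
- compound 3 `CNc1nccc(N2CC[C@H](NC(=O)Nc3ccc(C)c(Cl)c3)C2)n1`: 99.3%

In this assay compound 1 at 94.3% lies between compound 2 at 80% and compound 3 at 99.3%.

Compound 4 `CNc1nccc(N2CC[C@H](NC(=O)Nc3ccc(CN4CCC4)c(C(F)(F)F)c3)C2)n1` differs from compound 1 by azetidin-1-yl in place of dimethylamino on a saturated chain carbon bound to an aromatic carbon.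

Among the measured compounds shown here, the only measured step, a 29-fold lower unbound fraction from compound 2 to compound 3 (1.46 log units; beyond the scatter), is large, but it exchanges 4-methoxyphenyl for 3-chloro-4-methylphenyl and so bears only indirectly. For the measured compounds named here, no measured pair changes dimethylamino. No step beyond the scatter is therefore expected, and the estimated step is a 1.1-fold higher unbound fraction from compound 1 to compound 4 (0.02 log units; within the scatter). The estimate for compound 4 is 94%, with an expected range of 88% to 97.5%.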

Compound 4, plasma protein binding: 86.3%
Compound 4: middle estimate off by 2.3-fold (0.36 log units) (unbound fraction), on the low side; the measured number lies below the stated range.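

In this assay the terminal group on the saturated chain carbon bound to an aromatic carbon proves to matter: azetidin-1-yl in place of dimethylamino gives a 2.4-fold higher unbound fraction from compound 1 to compound 4 (0.38 log units; beyond the scatter) and so a modest step beyond the scatter. The earlier compounds shown here held no measured change at this place, and here a change confined to this one group moves binding with the rest of compound 1 held constant. No supporting evidence bears on why this step occurs.

Open, going by these compounds, is whether a larger ring such as pyrrolidin-1-yl or morpholin-4-yl at this place would continue the step or reverse it. Also open, on these data alone, is whether the step would persist with a group other than trifluoromethyl on the same aromatic ring.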